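The source may hold more compounds than are shown below. What is called first, only, known or untested is meant among the compounds shown, and "the series" means these compounds.

Compound 2 `COc1ccc(OC)c(/C=C/C(=O)N/N=C/c2ccc(Cl)cc2)c1` stands lowest of the two numbers measured in a functional assay on IGROV-1 cells (Homo sapiens) for antiproliferative activity, read by sulforhodamine B assay, with a stated time of 48 h (on this read-out lower numbers stand for stronger inhibition of growth and higher numbers for weaker inhibition of growth), at 187 nM; compound 1 `COc1ccc(OC)c(/C=C/c2nnc(Nc3ccc(Cl)cc3)o2)c1` gives 7700 nM, a gap beyond the usual scatter. Compound 3 `COc1ccc(OC)c(/C=C/C(=O)N/N=C/c2ccccc2)c1` has not yet been measured. Its difference from compound 2 is hydrogen in place of chloro on an aromatic carbon. Going by the values given here, no step between measured compounds resembles this change, so the direction is uncertain. A modest weakening is expected, with an estimated step of about a 2.1-fold higher number from compound 2 to compound 3 (0.33 log units; beyond the scatter). Compound 3 is therefore estimated at 400 nM, with a range from 100 nM to 1600 nM.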

Compound 3, concentration for 50% growth inhibition: 1510 nM
Compound 3: middle estimate off by 3.8-fold (0.58 log units), on the low side, and the stated range covers the measured number.
By their numbers in this assay, from the lowest: compound 2; then compound 3; then compound 1.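

Taking away the chloro, so that 4-chlorophenyl becomes phenyl, gives an 8.1-fold higher number from compound 2 to compound 3 (0.91 log units; beyond the scatter) in this assay. Going by these compounds alone, this is the first comparison here of compounds that differ in one place, and it shows that a single atom on this aromatic carbon, para to a large group, makes a clear difference to growth inhibition. Nothing available explains the size of this step.

As far as these compounds go, whether fluoro, methoxy or an amine at this place would match chloro remains open. So does whether chloro matters equally on the core of compound 1.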